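Solubility notes on an ester-linked pair and a morpholine analogue

The source may hold more compounds than are shown below. What is called first, only, known or untested is meant among the compounds shown, and "the series" means these compounds.

Measured so far:
compound 1 `CCOc1cc(NC(=O)C2(NC(=O)c3ccc4c(C5CCCC5)c(-c5ncc(Cl)cn5)n(C)c4c3)CCC2)ccc1/C=C/C(=O)OCCOCCOC` — in an ADME assay for solubility (a higher number here means a more soluble compound, a lower number a less soluble compound), compound 1 gives < 100000 ug/mL, which is a limit of the assay.
compound 2 `CCOc1cc(NC(=O)C2(NC(=O)c3ccc4c(C5CCCC5)c(-c5ncc(Cl)cn5)n(C)c4c3)CCC2)ccc1/C=C/C(=O)OCC(=O)N(C)C(C)C` — in this assay compound 2 gives < 200000 ug/mL, again a limit and not a number.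

Compound 2 therefore stands only at a limit in this assay; the other value shown, that of compound 1, is a limit as well, so neither compound has a point value. Among the compounds with values here, the single measured step, a step that the two limits leave unreadable from compound 1 to compound 2, is left unreadable by the two limits the limit of < 100000 ug/mL in this assay, at which 1 of the 2 values shown sits, and (the limit of < 200000 ug/mL in this assay, at which 1 of the 2 values shown sits).

Compound 3 `CCOc1cc(NC(=O)C2(NC(=O)c3ccc4c(C5CCCC5)c(-c5ncc(Cl)cn5)n(C)c4c3)CCC2)ccc1/C=C/C(=O)OCC(=O)N1CCOCC1` differs from compound 2 in one place: morpholin-4-yl in place of isopropyl(methyl)amino on a carbonyl carbon. Within the data shown here, no measured step bears on this change directly, and the one step that exists gives no readable size, so there is nothing here to set a direction. The expected step that the limit leaves unreadable from compound 2 to compound 3 is accordingly taken as none beyond the scatter. Compound 3 is estimated in this assay at 100000 ug/mL, with a range from 30000 ug/mL to 200000 ug/mL, and a further limit rather than a number is likely.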

Compound 3, solubility: < 15000 ug/mL
Compound 3 was reported as a limit; the forecaster's own chance of this, stated with the estimate: 70%; middle value at least 6.6-fold (0.82 log units) away from the limit.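

In this assay compound 3 gives < 15000 ug/mL, which is a limit and not a number. Within the data shown here, compound 1, compound 2 and compound 3 all stand at limits, so no step among them can be read. The compounds shown leave open where any of the three lies in this assay, and whether morpholin-4-yl in place of isopropyl(methyl)amino shifts the read-out at all.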